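Benzyl in place of methyl on compound 3

A few compounds are considered here, and "the series" means these few. Any claim that something is new, unique, unknown or untested is made for them only; others in the source may bear on it.

Of the compounds shown here, three have numbers so far. In a functional assay on B16 cells (Mus musculus) for cytotoxicity, read by MTT assay (on this read-out lower numbers stand for stronger inhibition and higher numbers for weaker inhibition), compound 1 `CC(=O)O[C@@H]1OC(=O)[C@](C)(C(C)=O)[C@@H]1C` gives 4000 nM. In this assay compound 2 `CC(=O)O[C@@H]1OC(=O)[C@](Cc2ccccc2)(C(C)=O)[C@@H]1C` gives 41000 nM. In this assay compound 3 `CC(=O)O[C@@H]1OC(=O)[C@@](C)(C(C)=O)[C@@H]1C` gives 14000 nM, the second highest of the three numbers, sitting between the values of compound 1 and compound 2. The step from compound 1 to compound 3 is a 3.5-fold higher number from compound 1 to compound 3 (0.54 log units; beyond the scatter), and it rests only on (the fact that compounds 1 and 3 differ only in the configuration as drawn). The step from compound 1 to compound 2 is a 10-fold higher number from compound 1 to compound 2 (1.01 log units; beyond the scatter).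

Compound 4 `CC(=O)O[C@@H]1OC(=O)[C@@](Cc2ccccc2)(C(C)=O)[C@@H]1C` is the unmeasured member; it differs from compound 3 by phenyl in place of hydrogen on a saturated chain carbon bound to a saturated ring carbon. Going by the values given here, the one measured step that bears on this change is a 10-fold higher number from compound 1 to compound 2 (1.01 log units; beyond the scatter), the same change carried out on compound 1, which per the fact that compounds 1 and 3 differ only in the configuration as drawn differs from compound 3 only in configuration. That step was large and beyond the scatter, so a step of similar size and direction is expected here: a 10-fold higher number from compound 3 to compound 4 (1.00 log units; beyond the scatter). Compound 4 is therefore expected at about 140000 nM in this assay, with a range of 45000 nM to 450000 nM.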

Compound 4, half-maximal inhibitory concentration: 45000 nM
Estimate against measurement, compound 4: 3.1-fold (0.49 log units) above; the range from low to high includes it.
By their numbers in this assay, from the lowest: compound 1; then compound 3; then compounds 2 and 4 (each within the scatter of the next).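

Methyl to benzyl on the second configuration gives a 3.2-fold higher number from compound 3 to compound 4 (0.51 log units; beyond the scatter) in this assay, so the direction holds on both configurations, but the size does not carry over: the same change on two cores in this assay, a 10-fold higher number (1.01 log units; beyond the scatter) from compound 1 to compound 2 and a 3.2-fold higher number (0.51 log units; beyond the scatter) from compound 3 to compound 4, 3.2-fold (0.50 log units) apart, beyond the scatter of two such steps. Going by these compounds alone, with benzyl in place, the configuration at the saturated ring carbon no longer separates the pair, at a 1.1-fold higher number from compound 2 to compound 4 (0.04 log units; within the scatter), whereas with methyl it gave a 3.5-fold higher number from compound 1 to compound 3 (0.54 log units; beyond the scatter): the fact that compounds 2 and 4 differ only in the configuration as drawn.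

The compounds shown carry only methyl and benzyl on this carbon, so it stays open how a longer chain such as phenethyl, or a benzyl bearing an amine or a carboxylic acid, would read here. On these data alone, it also stays open whether an ethyl group would keep the gap between the two configurations seen with methyl or close it as benzyl does.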